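Methoxy in Place of Methyl: What to Expect for Compound 4

A few compounds are considered here, and "the series" means these few. Any claim that something is new, unique, unknown or untested is made for them only; others in the source may bear on it.

compound 1 `COc1ccc(-c2cc(-c3ccc(F)cc3)nc(NC(=O)N/N=C\c3cccc(Cl)c3)n2)cc1OC`: 300 mg/kg
compound 2 `COc1ccc(-c2cc(-c3ccc(F)cc3)nc(NC(=O)N/N=C\c3ccccc3[N+](=O)[O-])n2)c(OC)c1`: 300 mg/kg
compound 3 `C/C(=N/NC(=O)Nc1nc(-c2ccc(F)cc2)cc(-c2ccc([N+](=O)[O-])cc2)n1)c1ccc(C)cc1`: 100 mg/kg

In a functional assay on the whole organism (strain Albino) with Mus musculus as the target, with a stated time of 0.5 h (a lower number here means that less compound is needed, a higher number that more compound is needed for the effect), compound 3 gives the lowest number of the three, and both compound 1 and compound 2 lie beyond the usual scatter above it, so compound 3 is the most potent measured here. Compound 4 `COc1ccc(/C(C)=N\NC(=O)Nc2nc(-c3ccc(F)cc3)cc(-c3ccc([N+](=O)[O-])cc3)n2)cc1` differs from compound 3 in one place: methoxy in place of methyl on an aromatic carbon. Going by the values given here, no measured pair shows this particular change, so the data give no direction for it. The expected step is therefore small, a 1.3-fold higher number from compound 3 to compound 4 (0.11 log units; within the scatter), not beyond the scatter. For compound 4 in this assay the estimate is 130 mg/kg, within a range from 60 mg/kg to 300 mg/kg.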

Compound 4, dose for half-maximal effect: 100 mg/kg
The estimate for compound 4 lay 1.3-fold (0.11 log units) above the measured number, within the range that was stated.
By their numbers in this assay, from the lowest: compounds 3 and 4 (each within the scatter of the next); then compounds 1 and 2 (each within the scatter of the next).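

Placing methoxy in place of methyl on this ring gives the first measured step at this position. In this assay the step reads (no change at the digits printed from compound 3 to compound 4 (within the scatter)), so going from 4-methylphenyl to 4-methoxyphenyl, which adds one oxygen and one hydrogen-bond acceptor, leaves the number within the scatter. Nothing available explains why the number holds at this position.

As far as these compounds go, only these two groups have been compared here, so an amine, a carboxylic acid or a longer chain at the same carbon remains open. From the compounds shown here alone, whether this change would behave the same way on another compound also remains open.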